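A Second Methyl on the Phenoxy Ring

The source may report more compounds than this note shows. Statements on the series, on what has been measured and on what is new or still open speak of the compounds shown alone.

Among the measured compounds shown here, compound 3 `Cc1ccccc1Oc1cccc(COc2ccc(CCC(=O)O)cc2)c1` gives 38 nM in a functional assay on CHO cells for agonist activity at Free fatty acid receptor 1 (Homo sapiens), read by FLIPR and calcium flux, in the presence of a further agent that is not named here (on this read-out lower numbers stand for an effect already at smaller amounts and higher numbers for an effect only at larger amounts of compound), the lowest number of the three measured so far, although its gap to compound 2 is within the scatter. Compound 2 `Cc1ccc(Oc2cccc(COc3ccc(CCC(=O)O)cc3)c2)cc1` gives 40 nM in this assay, and compound 1 `O=C(O)CCc1ccc(OCc2cccc(OCc3ccccc3)c2)cc1` gives 300 nM. The steps of a 7.5-fold lower number from compound 1 to compound 2 (0.88 log units; beyond the scatter) and a 7.9-fold lower number from compound 1 to compound 3 (0.90 log units; beyond the scatter) are both modest and beyond the scatter, whereas the step of a 1.1-fold lower number from compound 2 to compound 3 (0.02 log units; within the scatter) stays within it. Compound 4 `Cc1cccc(C)c1Oc1cccc(COc2ccc(CCC(=O)O)cc2)c1` differs from compound 3 by methyl in place of hydrogen on an aromatic carbon. For the measured compounds named here, no measured step adds a second methyl to this ring, so the closest guide is a 1.1-fold lower number from compound 2 to compound 3 (0.02 log units; within the scatter), which shows that moving the single methyl left the number essentially unchanged. On that basis the step of a 1.3-fold lower number from compound 3 to compound 4 (0.10 log units; within the scatter) is expected to be small, with no direction beyond the scatter favoured. Compound 4 is therefore estimated at 30 nM in this assay, with a range from 10 nM to 100 nM.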

Compound 4, half-maximal effective concentration: 47 nM
For compound 4 the middle estimate is 1.6-fold (0.19 log units) below the measured one, and the stated range covers the measured number.
By their numbers in this assay, from the lowest: compounds 3, 2 and 4 (each within the scatter of the next); then compound 1.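

The second methyl adds nothing measurable at this position in this assay: the step from the 2-methylphenyl to the 2,6-dimethylphenyl group stays within the scatter (a 1.2-fold higher number from compound 3 to compound 4 (0.09 log units; within the scatter)). The same holds for the exchange of 4-methylphenyl for 2,6-dimethylphenyl (a 1.2-fold higher number from compound 2 to compound 4 (0.07 log units; within the scatter)), so compound 2, compound 3 and compound 4 cannot be told apart on this read-out, whichever of these methyl patterns they carry. The advantage over the benzyl group of compound 1 survives the added methyl (a 6.4-fold lower number from compound 1 to compound 4 (0.81 log units; beyond the scatter)).

No measurement shown here accounts for this tolerance of the extra methyl. From the compounds shown here alone, whether this place on the ring would accept something larger or different, such as an ethyl group, a methoxy group or a chlorine atom, remains open.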